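Moving a chlorine on the aryl piperazine: a second test

A few compounds are considered here, and "the series" means these few. Any claim that something is new, unique, unknown or untested is made for them only; others in the source may bear on it.

Three compounds share a sequence of a lactam-bearing bicyclic core, a four-carbon chain and a piperazine carrying a chlorophenyl group. Compound 1 `CCC1(CCCCN2CCN(c3cccc(Cl)c3)CC2)C(=O)Nc2cc(F)c(Cl)cc21` and compound 2 `CCC1(CCCCN2CCN(c3ccc(Cl)cc3)CC2)C(=O)Nc2cc(F)c(Cl)cc21` have the same core, bearing an ethyl group and two halogens on the aromatic part, and differ only in where the chlorine sits on the phenyl ring. In an assay on membranes from frontal cortex for displacement of a labelled ligand from Adrenergic receptor alpha-1 (Rattus norvegicus), read by scintillation counting, with a stated time of 45 min (a lower number here means a stronger inhibitor, a higher number a weaker inhibitor), compound 1 gives 117 nM and compound 2 gives 191 nM. The change between them 4-chlorophenyl in place of 3-chlorophenyl on an amine nitrogen in a ring produced a 1.6-fold higher number from compound 1 to compound 2 (0.21 log units; within the scatter), so the two are not told apart by this measurement.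

Compound 3 `O=C1Nc2cc(F)ccc2C1CCCCN1CCN(c2cccc(Cl)c2)CC1` has a simpler core, with a single fluorine and no ethyl group; how its core differs from that of compound 1 is not broken down here. In this assay compound 3 gives 12.5 nM, the strongest binding of the three, with compound 1 and compound 2 both clearly weaker.

Compound 4 `O=C1Nc2cc(F)ccc2C1CCCCN1CCN(c2ccc(Cl)cc2)CC1` repeats on compound 3 the same change already seen from compound 1 to compound 2: 4-chlorophenyl in place of 3-chlorophenyl on an amine nitrogen in a ring. The place of the change is the same in both pairs. Since that change left compound 1 and compound 2 within the scatter of each other, compound 4 is expected to stay close to compound 3, with an expected step of a 1.6-fold higher number from compound 3 to compound 4 (0.20 log units; within the scatter) in this assay. The estimate for compound 4 in this assay is 20 nM, expected to lie between 9 nM and 45 nM.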

Compound 4, inhibition constant: 55 nM
Estimate against measurement, compound 4: 2.8-fold (0.44 log units) below; the measured number lies above the stated range.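

Moving the chlorine does not have the same measured outcome on both cores in this assay: on the simpler core, 4-chlorophenyl in place of 3-chlorophenyl gives a 4.4-fold higher number from compound 3 to compound 4 (0.64 log units; beyond the scatter), a real loss of binding, whereas on the core of compound 1 the same change could not be told apart from ordinary variation between repeated measurements. The size of the step therefore does not carry over unchanged from one core to the other, as the two steps set side by side show: the same change on two cores in this assay, a 1.6-fold higher number (0.21 log units; within the scatter) from compound 1 to compound 2 and a 4.4-fold higher number (0.64 log units; beyond the scatter) from compound 3 to compound 4, 2.7-fold (0.43 log units) apart, beyond the scatter of two such steps These numbers do not show which difference between the cores, the ethyl group or the added chlorine, goes with the larger step, and two pairs are too few to give a rule for any further core.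

A core carrying only the ethyl group, or only the added chlorine, and tested with each chlorophenyl group would be needed to separate those two differences. Also open, from the compounds shown here alone, is whether the pattern holds for a fluorine or a methoxy group in place of the chlorine on the phenyl ring, or for a longer chain between the core and the piperazine.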